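Aromatic urea to acrylamide: an untested step

The compounds below may be only part of what the source reports. "The series", "measured", "known", "first", "only" and "open" are said of these compounds alone.

Measured compounds:
compound 1 `O=C(NCCCCl)Nc1ccc(I)cc1` — 90000 nM
compound 2 `CC(C)(C)c1ccc(NC(=O)NCCCCl)cc1` — 28000 nM
compound 3 `CCCCC(O)c1cccc(NC(=O)NCCCCl)c1` — 19000 nM

In a functional assay on HT-29 cells (Homo sapiens) for antiproliferative activity, with a stated time of 48 h (on this read-out higher numbers stand for weaker inhibition and lower numbers for stronger inhibition), compound 2 gives 28000 nM. Among the three measured compounds its number is the second highest: compound 3 gives 19000 nM, which is within the scatter of compound 2, so no order can be read between those two, while compound 1 gives 90000 nM, and the step of a 3.2-fold lower number from compound 1 to compound 2 (0.51 log units; beyond the scatter) is beyond the scatter.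

Compound 4 `C=CC(=O)Nc1ccc(C(C)(C)C)cc1` has not been measured. It differs from compound 2 in one place: vinyl in place of (3-chloropropyl)amino on a carbonyl carbon. For the measured compounds named here, no measured step touches this part of the molecule; the only known step, a 3.2-fold lower number from compound 1 to compound 2 (0.51 log units; beyond the scatter), concerns a substituent on the aromatic carbon and leaves the urea untouched, so it does not bear on the present change. Going by the values given here, with no comparable step to lean on, the expectation for compound 4 in this assay is a number close to that of compound 2, with a wide range and no direction asserted beyond the scatter. The estimate for compound 4 is 30000 nM, between 8000 nM and 120000 nM. The expected step of a 1.1-fold higher number from compound 2 to compound 4 (0.03 log units; within the scatter) is thus set to be small.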

Compound 4, half-maximal inhibitory concentration: 24000 nM
Estimate against measurement, compound 4: 1.3-fold (0.10 log units) above, and the stated range covers the measured number.
By their numbers in this assay, from the lowest: compounds 3, 4 and 2 (each within the scatter of the next); then compound 1.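

In this assay, the exchange of (3-chloropropyl)amino for vinyl on a carbonyl carbon comes out as a 1.2-fold lower number from compound 2 to compound 4 (0.07 log units; within the scatter). For the compounds shown here, the earlier compounds all carry (3-chloropropyl)amino, so only this pair shows that, on the core of compound 2, the group can give way to vinyl with the two numbers staying within the scatter of each other. No measurement shown bears on what lies behind this result.

As far as these compounds go, whether an amine, a carboxylic acid or a longer chain on the same carbonyl carbon would stay within the scatter of compound 2 remains open. So does whether vinyl would read the same way on the cores of compound 1 and compound 3, which carry other groups on the aromatic ring.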